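The source may report more compounds than this note shows. Statements on the series, on what has been measured and on what is new or still open speak of the compounds shown alone.

Measured compounds:
- compound 1, `O=C(C1CC1)N1CCc2nc(C3(C(=O)Nc4ccc(F)cc4)CCC3)ccc21`: 8 nM
- compound 2, `COCCOC(=O)N1CCc2nc(C3(NC(=O)c4ccc(Cl)cc4)CCC3)ccc21`: 6.9 nM
- compound 3, `CC(C)C(=O)N1CCc2cc(CNC(=O)c3ccco3)ccc21`: 92 nM

Of the compounds shown here, three have been measured in an assay on HeLa cells for inhibition of Indoleamine 2,3-dioxygenase 1 (Homo sapiens); on this read-out higher numbers stand for weaker inhibition and lower numbers for stronger inhibition. Compound 1 gives 8 nM, the second highest of the three numbers. Its nearest neighbour is compound 2, which gives 6.9 nM; the two values lie within the scatter of each other, so nothing separates them. Compound 3 gives 92 nM, a clearly higher number, beyond the scatter, and thus the weakest inhibition of the three.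

Compound 4, `O=C(Nc1ccc(F)cc1)C1(c2ccc3c(n2)CCN3c2ccnc(C(F)(F)F)n2)CCC1`, has not yet been measured in this assay. It differs from compound 1 in one place: 2-(trifluoromethyl)pyrimidin-4-yl in place of cyclopropylcarbonyl on a nitrogen on an aromatic ring in a ring. The amide on the ring nitrogen of compound 1 is thus exchanged for an aromatic heterocycle bearing a trifluoromethyl group, while the rest of the molecule, including the fluorophenyl amide and the cyclobutane, is kept.

Going by the values given here, no measured pair shows what such an exchange does on this read-out, so the expectation rests on the fact that compounds 1 and 2 carry different groups at this nitrogen and still give values within the scatter of each other. Compound 4 is therefore expected to stay close to compound 1, with a step of a 1.3-fold lower number from compound 1 to compound 4 (0.12 log units; within the scatter) and no change beyond the scatter anticipated. The estimate for compound 4 in this assay is 6 nM, with a range from 1.5 nM to 25 nM.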

Compound 4, half-maximal inhibitory concentration: 127 nM
The estimate for compound 4 lay 21-fold (1.33 log units) below the measured number; measured number outside the range, above it.
By their numbers in this assay, from the lowest: compounds 2 and 1 (each within the scatter of the next); then compounds 3 and 4 (each within the scatter of the next).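

In this assay the nitrogen on an aromatic ring in a ring proves sensitive to what it carries: 2-(trifluoromethyl)pyrimidin-4-yl in place of cyclopropylcarbonyl gives a 16-fold higher number from compound 1 to compound 4 (1.20 log units; beyond the scatter) while the rest of the molecule stays the same. This is the only pair shown that differs at this position alone, and it gives the position a measured step, in the direction of weaker inhibition. No measurement available here explains why this exchange has so large an effect.

The exchange removes the carbonyl and the three-membered ring and brings in the pyrimidine ring and the trifluoromethyl group all at once, so the compounds shown leave open which of these parts accounts for the step. They also leave open what an unsubstituted pyrimidin-4-yl, a phenyl or an acetyl group on this nitrogen would give, and whether the 2-(trifluoromethyl)pyrimidin-4-yl group would produce a step of similar size on the core of compound 2.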